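A few compounds are considered here, and "the series" means these few. Any claim that something is new, unique, unknown or untested is made for them only; others in the source may bear on it.

Working notes on the series in a functional assay on A549 cells (Homo sapiens) for inhibition, read by MTT assay, with a stated time of 72 h; a lower number here means a stronger inhibitor, a higher number a weaker inhibitor. Compound 1 `COc1ccc(Nc2nc(Oc3cccc(NC(=O)/C=C/C(C)C)c3)c3sccc3n2)cc1` gives 37900 nM. For the measured compounds named here, compound 2 `COc1ccc(Nc2nc(Oc3cccc(NC(=O)C=C(C)C)c3)c3sccc3n2)cn1` gives in this assay 40100 nM, the highest of the two numbers so far; its nearest neighbour is compound 1, and the gap between the two lies within the scatter, so no order between them can be claimed. Compound 1 and compound 2 differ in two places at once, so no single step can be read from the pair; their two values simply sit close together.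

Compound 3 `COc1ccc(Nc2nc(Oc3cccc(NC(=O)/C=C/C(C)C)c3)c3sccc3n2)cn1` remains to be measured. It differs from compound 2 by 3-methylbut-1-en-1-yl in place of 2-methylprop-1-en-1-yl on a carbonyl carbon. Because compound 1 already carries this acyl group and gives 37900 nM, the weak inhibition seen in both measured compounds gives no sign that this change moves the number. The step from compound 2 to compound 3 is expected to be none beyond the scatter, estimated as a 1.0-fold lower number from compound 2 to compound 3 (0.01 log units; within the scatter). Compound 3 is accordingly estimated at 39000 nM in this assay, with an expected range from 15000 nM to 100000 nM.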

Compound 3, half-maximal inhibitory concentration: > 50000 nM
Compound 3: only a limit was reported (the forecaster's own chance of this, stated with the estimate: 15%); middle value at least 1.2-fold (0.10 log units) from the limit.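

In this assay compound 3 gives > 50000 nM as its result, which is a limit of the assay and not a number. The series now has its first comparisons that differ in one place: with the 6-methoxypyridin-3-yl group held, the acyl change gives an at least 1.2-fold higher number from compound 2 to compound 3 (0.09 log units; that floor lies within the scatter) on the carbonyl carbon, and with the 3-methylbut-1-en-1-yl acyl group held, the change on the nitrogen gives an at least 1.3-fold higher number from compound 1 to compound 3 (0.12 log units; that floor lies within the scatter) as the reading. Neither floor establishes an order among the compounds, and neither change gives a lower number, so the size of each step remains bounded on one side only, with the upper end unknown: the limit of > 50000 nM in this assay, at which 1 of the 3 values shown sits.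

The compounds shown leave open whether any change at this acyl position can bring the number down, for instance a dimethylamino group or a carboxylic acid at the end of the chain, or a longer chain. They also leave open how far the aryl group on the nitrogen matters when it carries something other than methoxy, such as a fluorine or a morpholine ring.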